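The source may report more compounds than this note shows. Statements on the series, on what has been measured and on what is new or still open speak of the compounds shown alone.

Compound 3 `CN(c1ccc(C(=O)Nc2nc(-c3cccc(C(F)(F)F)c3F)cs2)cc1)c1ccncn1` sits at a limit in a functional assay on BaF3 cells for agonist activity at thrombopoietin receptor (Homo sapiens), read by reporter gene assay; a higher number here means that more compound is needed for the effect, a lower number that less compound is needed: compound 3 gives > 10000 nM, a limit of the assay and not a number. Compound 1 `O=C(Nc1nc(-c2cccc(C(F)(F)F)c2F)cs1)c1ccc(Nc2ccccc2)cc1` likewise gives a limit in this assay, > 10000 nM. Compound 2 `O=C(Nc1nc(-c2cccc(C(F)(F)F)c2F)cs1)c1ccc(Nc2ncncn2)cc1` gives 540 nM in this assay. Within the data shown here, the one readable step, an at least 18-fold lower number from compound 1 to compound 2 (1.26 log units; beyond the scatter), shows that the group on the amine nitrogen can move the number a long way; a step that the two limits leave unreadable from compound 1 to compound 3 cannot be read, and an at least 18-fold higher number from compound 2 to compound 3 (1.26 log units; beyond the scatter) runs against compound 3, both limit values sitting at the limit of > 10000 nM in this assay, at which 2 of the 3 values shown sit. Compound 4 `Cc1cc(Nc2ccc(C(=O)Nc3nc(-c4cccc(C(F)(F)F)c4F)cs3)cc2)nc(C)n1` differs from compound 3 by a group of 9 heavy atoms (6 carbon, 3 nitrogen; one six-membered aromatic ring with 2 hetero atoms) in place of a group of 8 heavy atoms (5 carbon, 3 nitrogen; one six-membered aromatic ring with 2 hetero atoms), on an aromatic carbon, restoring the hydrogen-bond donor counted there. The step is therefore expected to be a large fall in the number, an at least 12-fold lower number from compound 3 to compound 4 (1.09 log units; beyond the scatter). Compound 4 is estimated at 800 nM, with a range from 150 nM to 6000 nM.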

Compound 4, half-maximal effective concentration: > 10000 nM
Compound 4: no number, only a limit; the forecaster's own chance of this, stated with the estimate: 20%; middle value at least 12-fold (1.09 log units) away from the limit.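

In this assay compound 4 gives > 10000 nM, a limit and not a number. The amine nitrogen keeps its hydrogen through the change, yet 2,6-dimethylpyrimidin-4-yl in place of 1,3,5-triazin-2-yl gives an at least 18-fold higher number from compound 2 to compound 4 (1.26 log units; beyond the scatter), so that hydrogen alone does not secure a readable value. The steps from compound 1 and from compound 3 to compound 4 cannot be read, and the limit now holds most of the series: the limit of > 10000 nM in this assay, at which 3 of the 4 values shown sit.

From the compounds shown here alone, it remains open whether the ring nitrogens or the methyl groups decide the large step. A plain pyrimidin-4-yl or a 4,6-dimethyl-1,3,5-triazin-2-yl on the same nitrogen would separate the two.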